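Ethyl on an Amide Nitrogen in Two Related Cores

This account rests on a few compounds, and the source may have more. Where it says the series, first, only, none or still open, it means among the compounds named here.

Compound 1, `CCNC(=O)C1=C(C)NC(=O)NC1c1ccco1`: 1%
Compound 2, `CCN(CC)C(=O)C1=C(C)NC(=O)NC1c1ccco1`: 31%
Compound 3, `CC1=C(C(N)=O)C(c2ccoc2)NC(=O)N1`: 6%

All three compounds were tested in an assay on membranes from HEK293 cells for displacement of a labelled ligand from adenosine receptor A2b (Homo sapiens), read by scintillation counting, with a stated time of 30 min, tested at 1 uM; a lower number here means less inhibition, a higher number more inhibition at the concentration tested (going by the name of the read-out). Compound 1 gives 1%, and compound 2 gives 31%. The two differ in one place, (ethyl in place of hydrogen on an amide-type nitrogen), and this change makes a step of a number 30 percentage points higher from compound 1 to compound 2 (beyond the scatter). Compound 3 gives 6% in this assay; its number and that of compound 1 lie within the usual scatter of each other, while compound 2 stands clearly higher than both. How the core of compound 3 differs from the core of compound 1 is not broken down here.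

Compound 4, `CCNC(=O)C1=C(C)NC(=O)NC1c1ccoc1`, has not yet been measured in this assay. It differs from compound 3 by ethyl in place of hydrogen on an amide-type nitrogen. For the measured compounds named here, this is the same kind of change as the one from compound 1 to compound 2, but not the same: in the earlier pair the amide-type nitrogen also carried a saturated chain carbon, whereas in compound 3 its only other neighbour is the carbonyl carbon.

Because the earlier ethyl step gave a number 30 percentage points higher from compound 1 to compound 2 (beyond the scatter), some rise is expected from compound 3 to compound 4, though the different surroundings of the nitrogen and the low starting point of compound 3 leave it uncertain; the step expected is a number 6 percentage points higher from compound 3 to compound 4 (within the scatter). Compound 4 is therefore estimated at 12%, within a range from 0% to 30%.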

Compound 4, a percentage reported as inhibition, at one concentration (the size of the read-out at that concentration, not a potency): 2%
The estimate for compound 4 lay 10 percentage points above the measured number, and the stated range covers the measured number.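

Ethyl in place of hydrogen on an amide-type nitrogen does not carry over with the same result from one core to the other in this assay: the same change on two cores in this assay, a number 30 percentage points higher (beyond the scatter) from compound 1 to compound 2 and a number 4 percentage points lower (within the scatter) from compound 3 to compound 4, 34 percentage points apart, beyond the scatter of two such steps

With the furan-3-yl group, the change gives a step of a number 4 percentage points lower from compound 3 to compound 4 (within the scatter), so the rise seen in the earlier pair does not appear here, and furan-3-yl in place of furan-2-yl on a saturated ring carbon gives a step of a number 1 percentage points higher from compound 1 to compound 4 (within the scatter), which leaves the furan swap alone without a readable effect between these two compounds. This does not show what makes the two ethyl steps differ, since the pairs differ in two ways at once: the furan group they carry, and whether the nitrogen already holds an ethyl group or only the carbonyl carbon and hydrogens.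

The compounds shown leave open whether a further ethyl on the amide nitrogen of compound 4 would give a rise like the one in the earlier pair, which would help separate those two differences. They also leave open how a longer chain such as butyl, or a cyclic amine such as piperidine forming the amide, would read in this assay.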